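The compounds below may be only part of what the source reports. "The series", "measured", "known", "first", "only" and "open" are said of these compounds alone.

In a toxicity assay on KB cells (Homo sapiens) for cytotoxicity, read by fluorescence, with a stated time of 3 days (on this read-out higher numbers stand for an effect only at larger amounts of compound and lower numbers for an effect already at smaller amounts), compound 1 `CCCCOC(=O)CNC(=O)[C@H](CSc1ccc([N+](=O)[O-])cc1[N+](=O)[O-])NC(=O)CC[C@H](NC(=O)OC(C)(C)C)C(=O)OCCCC` gives 70.4 uM. Compound 2 `CCCCCCCCCCCCCC(=O)N[C@@H](CCC(=O)N[C@@H](CSc1ccc([N+](=O)[O-])cc1[N+](=O)[O-])C(=O)NCC(=O)OCCCC)C(=O)OCCCC` gives > 300 uM, which is a limit of the assay and not a number. Its standing is the limit of > 300 uM in this assay, at which 1 of the 2 values shown sits. Compound 3 `CCCCOC(=O)CNC(=O)[C@H](CSc1ccc([N+](=O)[O-])cc1[N+](=O)[O-])NC(=O)CC[C@H](NC(=O)CCc1ccccc1)C(=O)OCCCC` differs from compound 2 in one place: phenyl in place of undecyl on a saturated chain carbon, two bonds along the chain from a carbonyl carbon. Among the compounds with values here, a move towards lower numbers in this assay is expected, resting on compound 1 at 70.4 uM, the only measured number available. The estimated step is an at least 3.7-fold lower number from compound 2 to compound 3 (0.57 log units; beyond the scatter). The expected value for compound 3 is 80 uM, with an estimated range from 25 uM to 250 uM.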

Compound 3, concentration for half-maximal effect: > 300 uM
Compound 3: no number, only a limit; the forecaster's own chance of this, stated with the estimate: 20%; middle value at least 3.7-fold (0.57 log units) from the limit.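

Within the data shown here, replacing tert-butoxy with phenethyl on a carbonyl carbon gives, in this assay, an at least 4.2-fold higher number from compound 1 to compound 3 (0.62 log units; beyond the scatter), the first readable step in this set. Compound 3 gives > 300 uM, which is a limit of the assay and not a number. The step from undecyl to phenyl cannot be read, and the values now gather at the top of the range: the limit of > 300 uM in this assay, at which 2 of the 3 values shown sit.

As far as these compounds go, how far compound 2 and compound 3 lie past that limit stays open. From the compounds shown here alone, it also stays open whether an amine or a carboxylic acid at this place would give a measurable number.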